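This account rests on a few compounds, and the source may have more. Where it says the series, first, only, none or still open, it means among the compounds named here.

Measured in a physicochemical assay for lipophilicity, measured as octanol-water partition, at pH 7.4; on this read-out lower numbers stand for lower lipophilicity and higher numbers for higher lipophilicity:

- compound 1 `O=C([C@H](O)CS(=O)(=O)c1ccc2cc(Cl)ccc2c1)N1CCC(N2CCOC2=O)CC1`: 1.75
- compound 2 `O=C([C@H](O)CS(=O)(=O)c1ccc2cc(Cl)ccc2c1)N1CCC(N2CCCC2=O)CC1`: 1.96
- compound 3 `O=C([C@H](O)CS(=O)(=O)c1ccc2cc(Cl)ccc2c1)N1CCC(N2CCCC2)CC1`: 1.56

On these numbers, compound 3 cannot be told apart from compound 1, while it clearly lies under compound 2. The next compound to be measured in this assay is compound 4 `O=C([C@H](O)CS(=O)(=O)c1ccc2cc(Cl)ccc2c1)N1CCC(N2NCCCC2=O)CC1`, where the change is a group of 7 heavy atoms (4 carbon, 2 nitrogen, 1 oxygen; one six-membered non-aromatic ring with 2 hetero atoms) in place of a group of 5 heavy atoms (4 carbon, 1 nitrogen; one five-membered non-aromatic ring with 1 hetero atom), on a saturated ring carbon. For the measured compounds named here, its new group, a six-membered non-aromatic ring with 2 hetero atoms, has no measured counterpart, so the three known swaps on this saturated ring carbon are only a loose guide. Two are small, a number 0.21 log units higher from compound 1 to compound 2 (within the scatter) and a number 0.19 log units lower from compound 1 to compound 3 (within the scatter), and the largest is modest, a number 0.40 log units lower from compound 2 to compound 3 (beyond the scatter). Compound 4 is therefore expected to stay close to the span marked by compound 3 at 1.56 and compound 2 at 1.96. The expected change is a number 0.09 log units higher from compound 3 to compound 4 (within the scatter), a slight rise that is not expected to exceed the scatter. Compound 4 is estimated at 1.65, with an expected range from 1.25 to 2.05.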

Compound 4, distribution coefficient: 1.85
Estimate against measurement, compound 4: 0.20 log units below, within the range that was stated.
By their numbers in this assay, from the lowest: compounds 3, 1, 4 and 2 (each within the scatter of the next, the first and the last beyond it).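

In this assay, the new six-membered ring with 2 hetero atoms on this saturated ring carbon cannot be told apart from any of the three earlier groups (a number 0.29 log units higher from compound 3 to compound 4 (within the scatter); a number 0.11 log units lower from compound 2 to compound 4 (within the scatter); a number 0.10 log units higher from compound 1 to compound 4 (within the scatter)). Compound 4 therefore overlaps both compound 3 and compound 2, although those two remain clearly apart, so a larger ring that also carries a hydrogen-bond donor still gives a number inside the span already seen at this position. Nothing available here explains this outcome.

The compounds shown do not separate the larger ring from the second ring nitrogen, a comparison that 2-oxopiperidin-1-yl would supply. Going by these compounds, how a carboxylic acid or an open-chain amine would read on this carbon also stays open.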